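This account rests on a few compounds, and the source may have more. Where it says the series, first, only, none or still open, it means among the compounds named here.

Three amides on one shared core have been read so far in a functional assay on MCF7 cells (Homo sapiens) for inhibition, read by MTT assay; on this read-out higher numbers stand for weaker inhibition of growth and lower numbers for stronger inhibition of growth. There compound 1 `COc1cc2oc(-c3cccc(NC(=O)c4ccccc4Br)c3)cc(=O)c2c(OC)c1OC` gives 55000 nM while compound 2 `COc1cc2oc(-c3cccc(NC(=O)c4ccc(Cl)cc4)c3)cc(=O)c2c(OC)c1OC` gives 8780 nM and compound 3 `COc1cc2oc(-c3cccc(NC(=O)c4ccc(C#N)cc4)c3)cc(=O)c2c(OC)c1OC` gives 12700 nM as its reading. Compound 3 thus sits with compound 2 and shows no real separation from it, the gap being a 1.4-fold higher number from compound 2 to compound 3 (0.16 log units; within the scatter). Only compound 1 stands apart, through a 6.3-fold lower number from compound 1 to compound 2 (0.80 log units; beyond the scatter) and a 4.3-fold lower number from compound 1 to compound 3 (0.64 log units; beyond the scatter).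

Compound 4 `COc1cc2oc(-c3cccc(NC(=O)c4ccc(C)cc4)c3)cc(=O)c2c(OC)c1OC` keeps all of compound 3 except one group, with methyl in place of cyano on an aromatic carbon, para to a large group: methyl in place of cyano on an aromatic carbon. For the measured compounds named here, no compound with methyl at this place has been measured. The closest evidence is the exchange at the same place, where compound 3 differs from compound 2 by a 1.4-fold higher number from compound 2 to compound 3 (0.16 log units; within the scatter) and so stays within the scatter. The two larger steps replace 2-bromophenyl and therefore bear on this change only loosely. No step beyond the scatter is thus expected in this assay. The expected change is a 1.1-fold lower number from compound 3 to compound 4 (0.02 log units; within the scatter). For compound 4 the estimated value is 12000 nM, with an expected range from 5500 nM to 28000 nM.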

Compound 4, concentration for 50% growth inhibition: 8320 nM
Compound 4: middle estimate off by 1.4-fold (0.16 log units), on the high side; low and high end bracket the measured number.
By their numbers in this assay, from the lowest: compounds 4, 2 and 3 (each within the scatter of the next); then compound 1.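

With methyl now at the aromatic carbon para to a large group, this place has carried cyano, chloro and methyl, and this assay does not separate them: there is a 1.5-fold lower number from compound 3 to compound 4 (0.18 log units; within the scatter), and likewise a 1.1-fold lower number from compound 2 to compound 4 (0.02 log units; within the scatter). The earlier compounds had shown this only for the exchange of chloro and cyano, whereas here the nitrile leaves with its 2 heavy atoms, its triple bond and its hydrogen-bond acceptor, and methyl enters with 1 heavy atom and no acceptor, without a step beyond the scatter. The 2-bromophenyl amide still stands apart, with a 6.6-fold lower number from compound 1 to compound 4 (0.82 log units; beyond the scatter) as a third step of this kind beyond the scatter alongside those to compound 2 and compound 3, but nothing measured here explains either the closeness of the three readings or the distance of compound 1.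

On these data alone, whether a group such as an amine, a carboxylic acid or a longer chain at this place would also stay within the scatter remains open. Also open, as far as these compounds go, is whether the weaker reading of compound 1 goes with the bromo group itself or with where it sits on the ring.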